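The source may hold more compounds than are shown below. What is called first, only, known or untested is meant among the compounds shown, and "the series" means these compounds.

Measured compounds in an ADME assay on the whole organism for cytotoxicity, with Artemia salina as the target, with a stated time of 24 h; a lower number here means that less compound is needed, a higher number that more compound is needed for the effect:
- compound 1, `CCOc1cc(/C=C/C(=O)c2ccccc2NC(=O)NS(=O)(=O)c2ccc(C)cc2)ccc1O`: 19.2 ug/mL
- compound 2, `Cc1ccc(S(=O)(=O)NC(=O)Nc2ccccc2C(=O)/C=C/c2cccc(F)c2)cc1`: 4.13 ug/mL
- compound 3, `Cc1ccc(S(=O)(=O)NC(=O)Nc2ccccc2C(=O)/C=C/c2ccc(F)cc2)cc1`: 3.96 ug/mL

Compound 3 has the lowest number of the three in this assay; compound 2 sits next to it, and the two are within the scatter of each other, so no order between them can be read. Compound 1 stands apart, as shown by a 4.8-fold lower number from compound 1 to compound 3 (0.69 log units; beyond the scatter) and a 4.6-fold lower number from compound 1 to compound 2 (0.67 log units; beyond the scatter).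

Compound 4, `Cc1ccc(S(=O)(=O)NC(=O)Nc2ccccc2C(=O)/C=C/c2cccnc2)cc1`, is not yet measured. It differs from compound 3 in one place: pyridin-3-yl in place of 4-fluorophenyl on a double-bonded chain carbon bound to a double-bonded chain carbon. Of the measured steps, the one that most resembles this change is the swap of one aryl group for another at the same place, a 1.0-fold lower number from compound 2 to compound 3 (0.02 log units; within the scatter), which stayed within the scatter. The larger steps from compound 1 involved a different kind of group and give less direct guidance.

On this basis compound 4 is expected to land near compound 3, with a step of a 1.5-fold higher number from compound 3 to compound 4 (0.18 log units; within the scatter) that need not exceed the scatter. The estimated value for compound 4 in this assay is 6 ug/mL, within a range from 2.5 ug/mL to 15 ug/mL.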

Compound 4, concentration for half-maximal effect: 14.1 ug/mL
Compound 4: the middle estimate sits 2.4-fold (0.37 log units) below what was measured, and the stated range covers the measured number.
By their numbers in this assay, from the lowest: compounds 3 and 2 (each within the scatter of the next); then compounds 4 and 1 (each within the scatter of the next).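

In this assay the two fluorophenyl groups had made this place, on a double-bonded chain carbon bound to a double-bonded chain carbon, look tolerant of aryl swaps, yet with a 3.6-fold higher number from compound 3 to compound 4 (0.55 log units; beyond the scatter) and a 3.4-fold higher number from compound 2 to compound 4 (0.53 log units; beyond the scatter) the change to pyridin-3-yl shows that one aromatic ring cannot simply stand in for another. With a 1.4-fold lower number from compound 1 to compound 4 (0.13 log units; within the scatter) the pyridin-3-yl group cannot be told apart from 3-ethoxy-4-hydroxyphenyl, so among these four compounds only the two fluorophenyl groups give the lower numbers. Nothing measured here accounts for the step from the fluorophenyl rings to the pyridin-3-yl ring.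

Still open, as far as these compounds go, is whether a plain phenyl would group with the fluorophenyl compounds or with compound 4. Also open, from the compounds shown here alone, is whether pyridin-4-yl or pyridin-2-yl would give a number like that of compound 4.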